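Nitrogen substituent series: isopropyl to phenyl

The compounds below may be only part of what the source reports. "The series", "measured", "known", "first", "only" and "open" are said of these compounds alone.

The series shares the core of compound 1 `CCOC(=O)c1ccc(-c2nn(CC)c3ccccc23)cc1`. In a functional assay on cells (Platelet, Homo sapiens) for inhibition (on this read-out lower numbers stand for stronger inhibition and higher numbers for weaker inhibition), compound 1 gives > 10000 nM, which is a limit of the assay and not a number. Compound 2 `CCOC(=O)c1ccc(-c2nn(C(C)C)c3ccccc23)cc1` is reached by the step that the two limits leave unreadable from compound 1 to compound 2, whose size cannot be read. In this assay compound 2 gives > 10000 nM, again a limit of the assay rather than a number. Among the measured compounds shown here, compound 2 thus stands at the limit, as does the one other value shown, per (the limit of > 10000 nM in this assay, at which 2 of the 2 values shown sit). Compound 3 `CCOC(=O)c1ccc(-c2nn(-c3ccccc3)c3ccccc23)cc1` differs from compound 2 by phenyl in place of isopropyl on an aromatic nitrogen. For the measured compounds named here, the only measured step, from compound 1 to compound 2, is unreadable, so no measured step sets the size of the step to compound 3 in this assay; any expectation rests on the two limits alone. For compound 3 the expected step is a number no higher from compound 2 to compound 3 (the limit leaves the size open), meaning no readable move is expected. For compound 3 the estimate in this assay is 10000 nM, within 2000 nM to 50000 nM.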

Compound 3, half-maximal inhibitory concentration: > 10000 nM
Compound 3 gave a limit, no number (the forecaster's own chance of this, stated with the estimate: 70%); the middle value lies on the limit itself.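

In this assay compound 3 gives > 10000 nM, a limit and not a number. The steps among compound 1, compound 2 and compound 3 cannot be read: the limit of > 10000 nM in this assay, at which 3 of the 3 values shown sit.

Still open, on these data alone, is how ethyl, isopropyl and phenyl on the aromatic nitrogen rank against each other.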